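The compounds below may be only part of what the source reports. "The series", "measured", "known", "first", "only" and "open" are said of these compounds alone.

Within the data shown here, in a functional assay on HeLa cells (Homo sapiens) for antiproliferative activity, read by MTT assay, with a stated time of 48 h (on this read-out lower numbers stand for stronger inhibition and higher numbers for weaker inhibition), three compounds sharing one core have numbers so far. Compound 1 (`CN(C)CCCn1c(N)c(-c2nc3ccccc3[nH]2)c2nc(C#N)c(C#N)nc21`) gives 25900 nM, compound 2 (`CN(C)CCCn1c(N)c(-c2nc3ccccc3o2)c2nc(C#N)c(C#N)nc21`) gives 11200 nM, and compound 3 (`CCN(CC)CCCCn1c(N)c(-c2nc3ccccc3o2)c2nc(C#N)c(C#N)nc21`) gives 6420 nM. Compound 2 therefore stands clearly below compound 1, while compound 2 and compound 3 cannot be told apart on these numbers.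

Compound 4 (`CN(C)CCCn1c(N)c(-c2nc3ccccc3s2)c2nc(C#N)c(C#N)nc21`), not yet measured, alters one group of compound 2: 1,3-benzothiazol-2-yl in place of 1,3-benzoxazol-2-yl on an aromatic carbon. Sulfur takes the place of oxygen, and the counts of heavy atoms and hydrogen-bond acceptors stay the same.

The closest evidence comes from the same place, where 1,3-benzoxazol-2-yl replaced 1H-benzimidazol-2-yl and gave a modest change, a 2.3-fold lower number from compound 1 to compound 2 (0.36 log units; beyond the scatter). The other step, a 1.7-fold lower number from compound 2 to compound 3 (0.24 log units; within the scatter), lies on the saturated chain and bears on this swap only weakly. Among the measured compounds shown here, no measured compound carries sulfur, so the direction is uncertain, and no change beyond the scatter is expected in this assay. The expected step is a 1.2-fold lower number from compound 2 to compound 4 (0.09 log units; within the scatter). The estimate for compound 4 is 9000 nM, with an expected range of 3500 nM to 24000 nM.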

Compound 4, half-maximal inhibitory concentration: 720 nM
The estimate for compound 4 lay 13-fold (1.10 log units) above the measured number; measured number outside the range, below it.
By their numbers in this assay, from the lowest: compound 4; then compounds 3 and 2 (each within the scatter of the next); then compound 1.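

In this assay, among these compounds, the group on this aromatic carbon matters far more than the earlier compounds indicated: exchanging one ring atom, oxygen for sulfur, while the counts of heavy atoms and hydrogen-bond acceptors stay the same, gives a 16-fold lower number from compound 2 to compound 4 (1.19 log units; beyond the scatter) and not the modest step seen before at this place. Measured against the 1H-benzimidazol-2-yl group, the 1,3-benzothiazol-2-yl group gives a 36-fold lower number from compound 1 to compound 4 (1.56 log units; beyond the scatter) so the choice of this fused ring group can shift the number by much more than the scatter. Nothing measured here explains why sulfur has so large an effect.

As far as these compounds go, it remains open whether this large step would persist with the diethylamino-ended chain of compound 3. Also unknown is how a chlorine or methoxy group on the carbon-only six-membered ring of the 1,3-benzothiazol-2-yl group would change the number.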